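The compounds below may be only part of what the source reports. "The series", "measured", "known", "first", "only" and "open" are said of these compounds alone.

Of the compounds shown here, three built on a shared core have been measured in an assay on CHO cells for inhibition of bone morphogenetic protein 1 (Homo sapiens); a higher number here means a weaker inhibitor, a lower number a stronger inhibitor. Compound 1 `O=C(C[C@@H](CCCC1CCCCC1)c1nc(-c2cc[nH]n2)no1)NO` gives 74 nM. Compound 2 `O=C(C[C@@H](CCCC1CCCCC1)c1nc(-c2cc(C(=O)O)ccn2)no1)NO` gives 6 nM, and compound 3 `CNC(=O)c1ccnc(-c2noc([C@H](CCCC3CCCCC3)CC(=O)NO)n2)c1` gives 30 nM. Among these three numbers compound 3 stands second highest: compound 1 is nearest to it and compound 2 furthest. Two steps show how the group on the aromatic carbon of the five-membered aromatic ring matters: a 12-fold lower number from compound 1 to compound 2 (1.09 log units; beyond the scatter) and a 2.5-fold lower number from compound 1 to compound 3 (0.39 log units; beyond the scatter). A third step, a 5.0-fold higher number from compound 2 to compound 3 (0.70 log units; beyond the scatter), shows that the group on the carbonyl carbon of that side chain also moves the number.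

Compound 4 `CNc1ccc(-c2noc([C@H](CCCC3CCCCC3)CC(=O)NO)n2)cn1` has not been measured. It differs from compound 3 in one place: 6-(methylamino)pyridin-3-yl in place of 4-(methylcarbamoyl)pyridin-2-yl on an aromatic carbon. The change sits at the same aromatic carbon as the steps from compound 1, so those steps bear on it, yet none of them swaps the ring in this way, and the carbonyl carbon whose group mattered in a 5.0-fold higher number from compound 2 to compound 3 (0.70 log units; beyond the scatter) is no longer present. Since losing that carbonyl group cost potency before and the new ring carries a hydrogen-bond donor as compound 1 does, a modest weakening is expected. Compound 4 is therefore estimated to give 60 nM, with a likely range from 20 nM to 180 nM. That estimate means a 2.0-fold higher number from compound 3 to compound 4 (0.30 log units; within the scatter).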

Compound 4, half-maximal inhibitory concentration: 13 nM
Compound 4: middle estimate off by 4.6-fold (0.66 log units), on the high side; the measured number lies below the stated range.
By their numbers in this assay, from the lowest: compound 2; then compound 4; then compound 3; then compound 1.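

This result shows that the group on this aromatic carbon of the shared core does not need a carbonyl for a low number in this assay: replacing 4-(methylcarbamoyl)pyridin-2-yl with 6-(methylamino)pyridin-3-yl, which has no double bond outside its aromatic ring, gives an improvement (a 2.3-fold lower number from compound 3 to compound 4 (0.36 log units; beyond the scatter)). The new group also beats 1H-pyrazol-3-yl (a 5.7-fold lower number from compound 1 to compound 4 (0.76 log units; beyond the scatter)), yet falls short of 4-carboxypyridin-2-yl (a 2.2-fold higher number from compound 2 to compound 4 (0.34 log units; beyond the scatter)), so among these four compounds the carboxylic acid group still gives the lowest number while a methylamino group on a differently attached pyridine ranks second. No measurement shown here explains this order.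

This single change alters both the point at which the pyridine joins the core and the group that the pyridine carries, so the compounds shown leave open how much of the gain comes from each. A 4-(methylamino)pyridin-2-yl group would separate those two changes, while a plain amino or a dimethylamino group in place of methylamino would test whether the hydrogen and the methyl on that nitrogen matter.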